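This account rests on a few compounds, and the source may have more. Where it says the series, first, only, none or still open, it means among the compounds named here.

Two compounds carry measurements in a functional assay on aorta for antagonist activity at Alpha-1D adrenergic receptor (Rattus norvegicus); on this read-out lower numbers stand for tighter binding and higher numbers for weaker binding. Compound 1 `Cc1ccc(N2CCN(CCCNc3ncccc3C(=O)N(C)C)CC2)c(-n2cccc2)c1` gives 12.6 nM there. Compound 2 `COc1cc(F)ccc1N1CCN(CCCNc2c(C(=O)N(C)C)cnc3c(C)cccc23)CC1` gives 316 nM in this assay, the higher of the two numbers; its nearest neighbour is compound 1, whose number is lower by a gap that lies beyond the usual scatter. Compound 2 and compound 1 differ in more than one place, so their pair shows only what the two values show. Compound 3 `COc1cc(F)ccc1N1CCN(CCCNc2c(C(=O)N(C)C)cnc3c(C(N)=O)cccc23)CC1` has not yet been measured in this assay. It differs from compound 2 by carbamoyl in place of methyl on an aromatic carbon. For the measured compounds named here, no measured pair in this set shows what such a change does here, so the size of the step remains uncertain. The step expected from compound 2 to compound 3 is estimated as a 1.3-fold lower number from compound 2 to compound 3 (0.10 log units; within the scatter), most likely not beyond the scatter. Compound 3 is therefore expected to give 250 nM in this assay, within a range from 60 nM to 1000 nM.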

Compound 3, dissociation constant: 158 nM
For compound 3 the middle estimate is 1.6-fold (0.20 log units) above the measured one, within the range that was stated.
By their numbers in this assay, from the lowest: compound 1; then compounds 3 and 2 (each within the scatter of the next).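

In this assay, for the compounds shown here, the pair gives the first reading of a single change on this core: carbamoyl in place of methyl on an aromatic carbon, ortho to a fused ring and meta to a fused ring, comes with a 2.0-fold lower number from compound 2 to compound 3 (0.30 log units; within the scatter) and stays within the scatter. The entering group brings a hydrogen-bond donor and a hydrogen-bond acceptor that methyl does not have, yet the read-out does not separate the two compounds. No other measurement at hand bears on why they read alike.

Going by these compounds, whether a carboxylic acid, a primary amine or a nitrile on this carbon would also read alike remains open. On these data alone, compound 1 differs from both in more than one place, so whether the same exchange holds on another core also stays open.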